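The source may report more compounds than this note shows. Statements on the series, on what has been measured and on what is new or still open speak of the compounds shown alone.

Going by the values given here, compound 2 `CS(=O)(=O)c1cc(C(=O)N=C(N)N)ccc1C(F)(F)F` is one of three compounds measured in a functional assay for inhibition of sodium/hydrogen exchanger (Oryctolagus cuniculus); a higher number here means a weaker inhibitor, a lower number a stronger inhibitor. In this assay compound 2 gives 140 nM. Compound 1 `Cc1cc(C(F)(F)F)c(S(C)(=O)=O)cc1C(=O)N=C(N)N` gives 37 nM, and compound 3 `Cc1ccc(S(C)(=O)=O)cc1C(=O)N=C(N)N` gives 150 nM, so the number of compound 2 stands second highest of the three, with compound 3 within the scatter of it and compound 1 beyond it. Compound 4 `CS(=O)(=O)c1cc(C(=O)N=C(N)N)ccc1N1CCCCC1` differs from compound 2 by piperidin-1-yl in place of trifluoromethyl on an aromatic carbon. Among the compounds with values here, only one measured step bears on this change: a 4.1-fold higher number from compound 1 to compound 3 (0.61 log units; beyond the scatter), which also removes a trifluoromethyl, there in compound 1. Within the data shown here, no measured step covers the entering piperidin-1-yl. A modest weakening is therefore expected for compound 4, a 1.8-fold higher number from compound 2 to compound 4 (0.25 log units; within the scatter). Compound 4 is estimated at 250 nM, in a range from 60 nM to 1000 nM.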

Compound 4, half-maximal inhibitory concentration: 130 nM
Compound 4: the middle estimate sits 1.9-fold (0.28 log units) above what was measured, within the range that was stated.
By their numbers in this assay, from the lowest: compound 1; then compounds 4, 2 and 3 (each within the scatter of the next).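

In this assay, piperidin-1-yl in place of trifluoromethyl gives a 1.1-fold lower number from compound 2 to compound 4 (0.03 log units; within the scatter) within the scatter. This position, ortho to a methylsulfonyl group, therefore accepts a six-membered non-aromatic ring in place of trifluoromethyl with no clear change in the number, unlike the replacement by hydrogen in the different setting of a 4.1-fold higher number from compound 1 to compound 3 (0.61 log units; beyond the scatter) where the number does rise. Nothing at hand explains why these two groups give such similar numbers.

On these data alone, whether a smaller amine such as dimethylamino or a carboxylic acid would fit here as well remains open. So does whether piperidin-1-yl would give the same result in the core of compound 1, which also carries a methyl.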